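Adding a methyl to the saturated ring carbon

The source may hold more compounds than are shown below. What is called first, only, known or untested is meant among the compounds shown, and "the series" means these compounds.

Compound 1 `CN1C(=O)COc2cc(Nc3cc4c(cn3)ncn4CC3CC3)ccc21`: > 1.66 h
Compound 2 `O=C1COc2cc(Nc3cc4c(cn3)ncn4CC3CC3)ccc2N1`: > 1.66 h

In an ADME assay on microsomes from liver (Homo sapiens) for metabolic stability (a higher number here means that the compound lasts longer, a lower number that the compound disappears faster), compound 1 gives > 1.66 h, which is a limit and not a number. Compound 2 gives > 1.66 h, also a limit. Within the data shown here, the position of the series so far is simply this: the limit of > 1.66 h in this assay, at which 2 of the 2 values shown sit.

Compound 3 `CC1Oc2cc(Nc3cc4c(cn3)ncn4CC3CC3)ccc2N(C)C1=O` departs from compound 1 as follows: methyl in place of hydrogen on a saturated ring carbon. Among the measured compounds shown here, the only measured step, a step that the two limits leave unreadable from compound 1 to compound 2, lies at a different place and gives no size to carry over. No step beyond the scatter is therefore expected.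

The expected change is a step that the limit leaves unreadable from compound 1 to compound 3. Compound 3 is estimated at 2 h. The estimated range for compound 3 runs from 1 h to 4 h.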

Compound 3, half-life: > 1.66 h
Compound 3: only a limit was reported; the forecaster's own chance of this, stated with the estimate: 65%; the middle value lies beyond the limit too.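

In this assay, among these compounds, compound 3 gives > 1.66 h, a limit and not a number, so no step from compound 1 to compound 3 can be read. Still open, going by these compounds, is how long compound 1, compound 2 and compound 3 actually last, and whether the added methyl changes that at all.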